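The source may hold more compounds than are shown below. What is called first, only, known or untested is meant among the compounds shown, and "the series" means these compounds.

Compound 1 `Cc1ccc(C(=O)N(CC(=O)NCc2ccccc2)Cc2ccc(C(=O)NO)cc2)c(C)c1`: 3710 nM
Compound 2 `CNC(=O)CN(Cc1ccc(C(=O)NO)cc1)C(=O)c1ccc(C(C)C)cc1`: 9160 nM
Compound 3 `Cc1ccc(C(=O)N(CC(=O)NC2CCCCC2)Cc2ccc(C(=O)NO)cc2)c(C)c1`: 8330 nM

In an ADME assay on HepG2 cells (Homo sapiens) for inhibition, read by luminescence and CellTiter-Glo, with stated times of 24 h and 48 h (a higher number here means a weaker inhibitor, a lower number a stronger inhibitor), compound 1 gives the lowest of the three numbers, and both other compounds lie beyond the scatter from it. Compound 4 `O=C(CN(Cc1ccc(C(=O)NO)cc1)C(=O)c1cccc2ccccc12)NCc1ccccc1` keeps the benzyl group of compound 1 and changes the group on the carbonyl carbon: naphthalen-1-yl in place of 2,4-dimethylphenyl on a carbonyl carbon. Going by the values given here, the one measured step, a 2.2-fold higher number from compound 1 to compound 3 (0.35 log units; beyond the scatter), is modest and concerns a different place, so it offers only a rough guide to size. From the compounds shown here alone, no measurement tests this change directly, and its direction is unknown, so no clear shift is expected in this assay. The expected step is a 1.1-fold lower number from compound 1 to compound 4 (0.03 log units; within the scatter). Compound 4 is estimated at 3500 nM, with an expected range of 1500 nM to 8000 nM.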

Compound 4, half-maximal inhibitory concentration: 12800 nM
Beside the measured number, compound 4's estimate is 3.7-fold (0.56 log units) below it, outside the stated range (above it).
By their numbers in this assay, from the lowest: compound 1; then compounds 3, 2 and 4 (each within the scatter of the next).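

In this assay the change on the carbonyl carbon gives a 3.5-fold higher number from compound 1 to compound 4 (0.54 log units; beyond the scatter) and so shows that this place, which no earlier single change had tested, is not neutral. Here the two-ring naphthalen-1-yl goes with a weaker inhibitor than the one-ring 2,4-dimethylphenyl, a step of modest size. No supporting data on the compounds account for this shift.

From the compounds shown here alone, whether an unsubstituted phenyl or a pyridine ring on this carbonyl carbon would give a lower or higher number remains open. So does whether the step would hold with cyclohexyl in place of benzyl.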